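Pyridylmethyl swap on the aminothiadiazole series

The source may hold more compounds than are shown below. What is called first, only, known or untested is meant among the compounds shown, and "the series" means these compounds.

Measured so far:
compound 2 `Cc1ccnc(Cc2cc(Nc3nc(C)cn4c(-c5cn[nH]c5)cnc34)sn2)c1`: 1850 ng.h/mL
compound 1 `Cc1cn2c(-c3cn[nH]c3)cnc2c(Nc2cc(Cn3cccn3)ns2)n1`: "not determined" (no result reported)

In an ADME assay on the whole organism for pharmacokinetics, with Rattus norvegicus as the target, with a stated time of 6 h, at a dose of 10 mg/kg by the oral route (a higher number here means more compound in the circulation at the dose given, a lower number less compound in the circulation), compound 2 gives 1850 ng.h/mL, the only figure in hand. For the measured compounds named here, compound 1 gives "not determined" (no result reported) in this assay, so no step between measured compounds can be stated. Compound 3 `Cc1cn2c(-c3cn[nH]c3)cnc2c(Nc2cc(Cc3ccc(F)cn3)ns2)n1` differs from compound 2 by 5-fluoropyridin-2-yl in place of 4-methylpyridin-2-yl on a saturated chain carbon bound to an aromatic carbon. With no measured change of this kind to lean on, the step is expected to be small and downward, within the usual scatter, as a 1.2-fold lower number from compound 2 to compound 3 (0.09 log units; within the scatter). Compound 3 is estimated at 1500 ng.h/mL, with a range of 500 ng.h/mL to 4500 ng.h/mL.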

Compound 3, area under the concentration-time curve: 2240 ng.h/mL
The estimate for compound 3 lay 1.5-fold (0.17 log units) below the measured number, within the range that was stated.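

At the saturated chain carbon bound to an aromatic carbon, 5-fluoropyridin-2-yl replaces 4-methylpyridin-2-yl with a 1.2-fold higher number from compound 2 to compound 3 (0.08 log units; within the scatter) in this assay, the first step readable at this position. The two groups are therefore not told apart by this read-out, and this position tolerates the exchange of one substituted pyridine ring for the other. Nothing measured here points to a cause for this result. Open, on these data alone, is whether a group of another kind on the same chain carbon, such as an amine or a carboxylic acid, would leave the number in this assay within the scatter of these two.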